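Aryl exchange from compound 3 to compound 4

The source may hold more compounds than are shown below. What is called first, only, known or untested is meant among the compounds shown, and "the series" means these compounds.

In a functional assay on DU-145 cells (Homo sapiens) for cytotoxicity, read by MTT assay, with a stated time of 48 h (a higher number here means a weaker inhibitor, a lower number a stronger inhibitor), compound 1 `C=C1CCC[C@]2(C)CCC(C=O)=CC[C@@]12C` gives 152000 nM. Compound 2 `C=C1CCC[C@]2(C)CCC(c3cn(-c4ccc(C(C)=O)cc4)nn3)=CC[C@@]12C` gives 51700 nM, and compound 3 `C=C1CCC[C@]2(C)CCC(c3cn(-c4cccc([N+](=O)[O-])c4)nn3)=CC[C@@]12C` gives 62500 nM. Compound 3 thus sits within the scatter of compound 2, and the values of both lie under that of compound 1.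

Compound 4 `C=C1CCC[C@]2(C)CCC(c3cn(-c4ccccc4C(C)=O)nn3)=CC[C@@]12C` carries 2-acetylphenyl in place of 3-nitrophenyl on an aromatic nitrogen of the five-membered aromatic ring with 3 nitrogen (2-acetylphenyl in place of 3-nitrophenyl on an aromatic nitrogen).

Among the measured compounds shown here, one measured step bears on this change: 3-nitrophenyl in place of 4-acetylphenyl gives a 1.2-fold higher number from compound 2 to compound 3 (0.08 log units; within the scatter). For the measured compounds named here, no compound measured so far carries 2-acetylphenyl, so the data leave that group untested. Going by the values given here, with only this one small step as a guide, no step beyond the scatter is expected in this assay, in either direction. The expected step is a 1.1-fold lower number from compound 3 to compound 4 (0.03 log units; within the scatter). Compound 4 is estimated at 58000 nM, with a range from 28000 nM to 120000 nM.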

Compound 4, half-maximal inhibitory concentration: 48500 nM
For compound 4 the middle estimate is 1.2-fold (0.08 log units) above the measured one, within the range that was stated.
By their numbers in this assay, from the lowest: compounds 4, 2 and 3 (each within the scatter of the next); then compound 1.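

In this assay, the new comparison is between two placements of the same acetyl group: 2-acetylphenyl in place of 4-acetylphenyl gives a 1.1-fold lower number from compound 2 to compound 4 (0.03 log units; within the scatter). Exchanging 3-nitrophenyl for 2-acetylphenyl gives a 1.3-fold lower number from compound 3 to compound 4 (0.11 log units; within the scatter), so a nitro group and an acetyl group are not separated here either. On the aromatic nitrogen of the five-membered aromatic ring with 3 nitrogen, compounds 2, 3 and 4 therefore form one group within the scatter, with none of the three going against this, and nothing available accounts for it.

From the compounds shown here alone, it remains open whether an aryl group carrying an amine or a carboxylic acid would move the number beyond the scatter. The same holds for a longer alkyl chain in place of the phenyl ring at this nitrogen.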